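The source may hold more compounds than are shown below. What is called first, only, known or untested is meant among the compounds shown, and "the series" means these compounds.

Measured so far:
Compound 1, `COc1ccc(Cc2nnc3sc(-c4ccnc(Cl)c4)nn23)cc1OC`, gives 11.2%.
Compound 2, `Cc1occc1-c1nnc2sc(-c3ccnc(Cl)c3)nn12`, gives 10.1%.

Both numbers come from a functional assay on the whole organism (strain Wistar Albino) for inhibition, with Rattus norvegicus as the target, read by paw edema, with a stated time of 1 h, at a dose of 20 mg/kg; on this read-out lower numbers stand for less inhibition and higher numbers for more inhibition at the one dose given (going by the name of the read-out). Compound 2 has the lower of the two values, but compound 1 sits within the scatter of it, so the two compounds cannot be told apart on this read-out; both show only weak inhibition of paw edema.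

Compound 3, `Cc1occc1-c1nnc2sc(-c3ccnc(F)c3)nn12`, is not yet measured. It differs from compound 2 in one place: fluoro in place of chloro on an aromatic carbon. For the measured compounds named here, the change is small, one halogen swapped for another on the same aromatic carbon, and no measured pair in this set shows what such a swap does here. With the two known compounds so close together, there is no basis for expecting a shift in either direction, so the step from compound 2 to compound 3 is expected to be no larger than the scatter, a number 0.1 percentage points lower from compound 2 to compound 3 (within the scatter). Compound 3 is therefore estimated at 10%, with a likely range from 3% to 20%.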

Compound 3, a percentage reported as inhibition, in the whole organism at one dose (the size of the read-out at that dose, not a potency): 16.7%
Compound 3: the middle estimate sits 6.7 percentage points below what was measured; the range from low to high includes it.
By their numbers in this assay, from the lowest: compounds 2, 1 and 3 (each within the scatter of the next).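

In this assay, the only halogen swap shown at this position, from 2-chloropyridin-4-yl to 2-fluoropyridin-4-yl, gives a number 6.6 percentage points higher from compound 2 to compound 3 (within the scatter). On this read-out, then, fluoro and chloro on this aromatic carbon, next to the ring nitrogen, cannot be told apart, and activity at this position survives the exchange of one halogen for the other, though a single pair shows no general trend. Nothing measured here bears on how either halogen acts at this position.

On these data alone, whether a different kind of group on this carbon, such as an amine or a methoxy group, would move the number beyond the usual scatter remains open. Also open, as far as these compounds go, is whether the same swap would give a similar step on compound 1, which carries a different group elsewhere on the core.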